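Series notes: aryl variation on the spiro hydrazide core

This account rests on a few compounds, and the source may have more. Where it says the series, first, only, none or still open, it means among the compounds named here.

Measured so far in a functional assay on HT-29 cells (Homo sapiens) for antiproliferative activity, read by MTT assay, with a stated time of 96 h; a higher number here means a weaker inhibitor, a lower number a stronger inhibitor:
compound 1 `O=C1NNC(=O)C2(CSC3=C2C(=O)c2ncccc2C3=O)N1`, 1580 nM; 1600 nM; 1600 nM (3 entries)
compound 2 `Cc1ccc(N2C(=O)NC3(CSC4=C3C(=O)c3ncccc3C4=O)C2=O)cc1`, 1 nM
compound 3 `O=C1NN(c2ccc([N+](=O)[O-])cc2)C(=O)C2(CSC3=C2C(=O)c2ncccc2C3=O)N1`, 1010 nM

Compound 1 has repeated entries, and the repeats agree closely: the several entries of compound 1 in this assay, 1580 nM; 1600 nM; 1600 nM (3 entries). Among the single numbers, compound 3 stands highest; the nearest is compound 2, with a lower number, a gap well beyond the scatter. Compound 1 sits without a single number.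

The next compound is compound 4 `Cc1ccc(N2NC(=O)NC3(CSC4=C3C(=O)c3ncccc3C4=O)C2=O)cc1`. It differs from compound 3 by methyl in place of nitro on an aromatic carbon; the nitro leaves and a methyl enters on the aromatic carbon para to a large group. Among the compounds with values here, no measured pair shows this change. For this assay a modest step toward a lower number is expected, about a 2.0-fold lower number from compound 3 to compound 4 (0.31 log units; beyond the scatter). Compound 4 is therefore estimated at 500 nM, between 100 nM and 2500 nM.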

Compound 4, half-maximal inhibitory concentration: 200 nM
For compound 4 the middle estimate is 2.5-fold (0.40 log units) above the measured one, and the stated range covers the measured number.
By their numbers in this assay, from the lowest: compound 2; then compound 4; then compound 3.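

In this assay, the change from 4-nitrophenyl to 4-methylphenyl gives a 5.1-fold lower number from compound 3 to compound 4 (0.70 log units; beyond the scatter), so the substituent on this aromatic carbon, para to a large group, does alter the read-out. Within the data shown here, this is the only pair so far that differs in one place, and so the first direct reading of this position. No measurement shown accounts for the size of the step.

Going by these compounds, it remains open how an amine or a carboxylic acid on the same aromatic carbon would read. A single pair also gives no trend across substituents at this position.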